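This account rests on a few compounds, and the source may have more. Where it says the series, first, only, none or still open, it means among the compounds named here.

Compound 1 `CC(C)CCn1c(Cn2c(=O)n(C3CC3)c3ccncc32)nc2nc(Cl)ccc21` — in an ADME assay on HeLa cells (Homo sapiens) for cytotoxicity, read by ATP content, with a stated time of 3 days (a higher number here means that more compound is tolerated, a lower number that less compound is tolerated), compound 1 gives only the limit > 50000 nM.
Compound 2 `N#CCCCn1c(Cn2c(=O)n(-c3ccc(C(=O)NC4CC4)cc3)c3ccncc32)cc2cc(Cl)ccc21` — compound 2 likewise gives a limit, > 50000 nM.
Compound 3 `CC(C)CCn1c(Cn2c(=O)n(C3CC3)c3ccncc32)nc2cccnc21` — compound 3 gives the limit > 100000 nM.

Compound 2 therefore stands at a limit of the assay rather than at a number, and the same holds for the other two values. Two of the three values sit at the limit of > 50000 nM in this assay, at which 2 of the 3 values shown sit, and one at the limit of > 100000 nM in this assay, at which 1 of the 3 values shown sits. For the measured compounds named here, no step between measured compounds is available for comparison. Compound 4 `N#CCCCn1c(Cn2c(=O)n(-c3ccc(C(=O)O)cc3)c3ccncc32)cc2cc(Cl)ccc21` differs from compound 2 in a single place: hydroxy in place of cyclopropylamino on a carbonyl carbon. All values here are limits, so no direction of the step can be read from them. Compound 4 is expected to show no change beyond the scatter, a step that the limit leaves unreadable from compound 2 to compound 4. Compound 4 is estimated at 60000 nM, within a range from 30000 nM to 120000 nM.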

Compound 4, half-maximal cytotoxic concentration: > 50000 nM
Compound 4: a limit, no number; the forecaster's own chance of this, stated with the estimate: 80%; the middle value is on the limit's open side.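

For the compounds shown here, compound 2 and compound 4 each give only a limit rather than a number, so no step between them can be read. The compounds shown leave open what concentration, if any, would harm the cells in this assay.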